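Swapping the Aryl Group on an Oxadiazole Ketone

The source may hold more compounds than are shown below. What is called first, only, known or untested is meant among the compounds shown, and "the series" means these compounds.

Compound 1 `O=C(CCCCCCc1ccccc1)c1ncno1` bears only hydrogen on the aromatic carbon of its five-membered core. In an assay on HEK-293T cells for inhibition of diacylglycerol lipase-alpha (Homo sapiens), read by colorimetric assay (a higher number here means a weaker inhibitor, a lower number a stronger inhibitor), compound 1 gives > 10000 nM, which is a limit of the assay and not a number. For the measured compounds named here, compound 2 `O=C(CCCCCCc1ccccc1)c1nc(-c2cccs2)no1` carries a thiophen-2-yl on that carbon, and in this assay compound 2 gives 1950 nM, the only number among the values shown. The other value shown is the limit of > 10000 nM in this assay, at which 1 of the 2 values shown sits, belonging to compound 1. The measured step is an at least 5.1-fold lower number from compound 1 to compound 2 (0.70 log units; beyond the scatter). Compound 3 `O=C(CCCCCCc1ccccc1)c1nc(-c2cccc(Br)n2)no1` has not yet been measured; it differs from compound 2 by 6-bromopyridin-2-yl in place of thiophen-2-yl on an aromatic carbon. No measured step exchanges one aromatic group for another at this carbon; the sole step shown, an at least 5.1-fold lower number from compound 1 to compound 2 (0.70 log units; beyond the scatter), concerns adding a group where hydrogen stood, so it bears only indirectly. A change within or slightly beyond the scatter is therefore expected in this assay, with no firm direction. Compound 3 is expected near 1500 nM, within a range from 400 nM to 6000 nM. The expected step is a 1.3-fold lower number from compound 2 to compound 3 (0.11 log units; within the scatter).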

Compound 3, half-maximal inhibitory concentration: 2040 nM
Compound 3: middle estimate off by 1.4-fold (0.13 log units), on the low side, and the stated range covers the measured number.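

For the compounds shown here, exchanging one aromatic group for another on this carbon, a change no earlier step covered, gives a 1.0-fold higher number from compound 2 to compound 3 (0.02 log units; within the scatter) in this assay, so thiophen-2-yl and 6-bromopyridin-2-yl cannot be told apart here. Set against hydrogen, 6-bromopyridin-2-yl gives an at least 4.9-fold lower number from compound 1 to compound 3 (0.69 log units; beyond the scatter), which shows that a step beyond the scatter is not confined to thiophen-2-yl. Compound 1 stands at a limit of the assay and not at a number, so the full size of the steps from it cannot be told: the limit of > 10000 nM in this assay, at which 1 of the 3 values shown sits.

From the compounds shown here alone, whether a plain phenyl, a pyridin-2-yl without the bromine or an amine on this carbon would read differently stays open. Also open, going by these compounds, is whether a shorter chain on the ketone would change what these aromatic groups do.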